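Fluoro in place of chloro: compound 3 to compound 4

The source may report more compounds than this note shows. Statements on the series, on what has been measured and on what is new or still open speak of the compounds shown alone.

For the measured compounds named here, compound 3 `O=C(NNC(=O)c1ccccc1Cl)c1cccc(NS(=O)(=O)c2cnc(O)nc2O)c1` gives 7300 nM in a functional assay on OVCAR-3 cells (Homo sapiens) for antiproliferative activity, read by MTT assay, with a stated time of 24 h (on this read-out higher numbers stand for weaker inhibition and lower numbers for stronger inhibition), the only actual number in this small set. Compound 1 `O=C(NNc1ccc(F)cc1)c1cccc(NS(=O)(=O)c2cnc(O)nc2O)c1` gives > 20000 nM, which is a limit and not a number. Compound 2 `Cc1ccccc1C(=O)NNC(=O)c1cccc(NS(=O)(=O)c2cnc(O)nc2O)c1` gives > 20000 nM, which is also a limit.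

Compound 4 `O=C(NNC(=O)c1ccccc1F)c1cccc(NS(=O)(=O)c2cnc(O)nc2O)c1` carries a single change: fluoro in place of chloro on an aromatic carbon, ortho to a large group.

The closest measured change is an at least 2.7-fold lower number from compound 2 to compound 3 (0.43 log units; beyond the scatter), with chloro in place of methyl on an aromatic carbon. Also relevant is an at least 2.7-fold lower number from compound 1 to compound 3 (0.43 log units; beyond the scatter), with (2-chlorophenyl)carbonyl in place of 4-fluorophenyl. Little can be taken from a step that the two limits leave unreadable from compound 1 to compound 2. Going by the values given here, no measured pair tests fluoro against chloro directly, but the step to compound 3 shows that this one substituent can shift the read-out. Among the compounds with values here, a small move toward a higher number is therefore favoured, with no step clearly beyond the scatter expected. A result given only as a limit remains possible for compound 4, given (the limit of > 20000 nM in this assay, at which 2 of the 3 values shown sit).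

The expected change is a 1.5-fold higher number from compound 3 to compound 4 (0.18 log units; within the scatter). For compound 4 the estimated value is 11000 nM, with an expected range of 4500 nM to 25000 nM.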

Compound 4, half-maximal inhibitory concentration: 10800 nM
The estimate for compound 4 lay 1.0-fold (0.01 log units) above the measured number, within the range that was stated.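

In this assay, the aromatic carbon ortho to a large group now has two halogens compared directly by actual numbers, and a 1.5-fold higher number from compound 3 to compound 4 (0.17 log units; within the scatter) shows that 2-chlorophenyl and 2-fluorophenyl cannot be told apart on this read-out. For the compounds shown here, earlier, the only readable steps at this site ended at compound 3 and rested on limits, so they could not show whether chloro alone gave a measurable reading; compound 4 shows that a measurable reading is not confined to chloro. The methyl comparison is less firm with fluoro, since an at least 1.8-fold lower number from compound 2 to compound 4 (0.26 log units; that floor lies within the scatter) and an at least 1.8-fold lower number from compound 1 to compound 4 (0.26 log units; that floor lies within the scatter) each give a floor only, so neither step separates compound 4 from the compound at the limit as clearly as the corresponding step to compound 3 does.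

Going by these compounds, whether bromo, methoxy or an amine on this same aromatic carbon would give a number or a limit stays open. Also open is how far compound 1 and compound 2 actually lie from the measured compounds, as their results are limits and not numbers: the limit of > 20000 nM in this assay, at which 2 of the 4 values shown sit.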